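The source may report more compounds than this note shows. Statements on the series, on what has been measured and on what is new or still open speak of the compounds shown alone.

Compound 2 `Nc1nn(C(=O)Nc2ccc(Cc3ccccc3)cc2)c2ccc(Cl)cc12` and compound 1 `Nc1nn(C(=O)Nc2ccc(Cc3ccccc3)cc2)c2ccccc12` share one core and differ only in a chloro in place of hydrogen on an aromatic carbon. In a functional assay on U-251 cells (Homo sapiens) for antiproliferative activity, read by sulforhodamine B assay, with a stated time of 48 h (on this read-out higher numbers stand for weaker inhibition of growth and lower numbers for stronger inhibition of growth), compound 1 gives 13900 nM, and compound 2 gives 12500 nM; the step of a 1.1-fold lower number from compound 1 to compound 2 (0.05 log units; within the scatter) is within the scatter, so compound 2 holds the lower of the two numbers without being separable from compound 1. Compound 3 `Nc1ccc2c(c1)c(N)nn2C(=O)Nc1ccc(Cc2ccccc2)cc1` is the next step, made from compound 2 by amino in place of chloro on an aromatic carbon. Among the measured compounds shown here, the only measured step that bears on it is the one from compound 1 to compound 2, which was within the scatter, and nothing measured speaks to an amino at this place. Compound 3 is therefore expected to give 12000 nM, between 4000 nM and 36000 nM, so that the expected step of a 1.0-fold lower number from compound 2 to compound 3 (0.02 log units; within the scatter) is none beyond the scatter.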

Compound 3, concentration for 50% growth inhibition: 6530 nM
Compound 3: the middle estimate sits 1.8-fold (0.26 log units) above what was measured, and the stated range covers the measured number.
By their numbers in this assay, from the lowest: compounds 3, 2 and 1 (each within the scatter of the next, the first and the last beyond it).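

With the amino on this aromatic carbon, the position gives its first step beyond the scatter: a 2.1-fold lower number from compound 1 to compound 3 (0.33 log units; beyond the scatter) in this assay, though the step is modest and the chloro in place of hydrogen had not left the scatter. So this carbon is not indifferent to what replaces its hydrogen, yet a 1.9-fold lower number from compound 2 to compound 3 (0.28 log units; within the scatter) remains within the scatter, which leaves the amino and the chloro unseparated here. Nothing available explains why the amino gives a step beyond the scatter where the chloro does not.

As far as these compounds go, whether a hydroxyl, a methoxy or an acetamide at this place would side with the amino or with the chloro stays open. Also open, from the compounds shown here alone, is whether an amino on another carbon of this ring would give a similar step.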